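Chlorophenyl in Place of Dimethylphenyl on the Ring Nitrogen

The source may report more compounds than this note shows. Statements on the series, on what has been measured and on what is new or still open speak of the compounds shown alone.

Three compounds have been measured in a functional assay on DU-145 cells (Homo sapiens) for cytotoxicity, read by MTT assay, with a stated time of 48 h; a higher number here means a weaker inhibitor, a lower number a stronger inhibitor:

Compound 1 `CCOC(=O)c1c(-c2c(Cl)c3ccccc3oc2=O)nn(-c2ccccc2)c1C(=O)OCC`: 48000 nM
Compound 2 `CCOC(=O)c1c(-c2c(Cl)c3ccccc3oc2=O)nn(-c2ccc(Br)cc2)c1C(=O)OCC`: 32000 nM
Compound 3 `CCOC(=O)c1c(-c2cc3ccccc3oc2=O)nn(-c2ccc(C)c(C)c2)c1C(=O)OCC`: 40000 nM

All three numbers lie within the usual scatter of one another, so compound 3 cannot be told apart from compound 1 or compound 2 on these data. Compound 4 `CCOC(=O)c1c(-c2cc3ccccc3oc2=O)nn(-c2ccc(Cl)cc2)c1C(=O)OCC` differs from compound 3 by 4-chlorophenyl in place of 3,4-dimethylphenyl on an aromatic nitrogen. Among the measured compounds shown here, the only measured change on that same aromatic ring is a 1.5-fold lower number from compound 1 to compound 2 (0.18 log units; within the scatter), a swap of one substituent for another that stayed within the scatter. The step to compound 4 is expected to be of the same kind, a 1.1-fold lower number from compound 3 to compound 4 (0.02 log units; within the scatter), because a 1.5-fold lower number from compound 1 to compound 2 (0.18 log units; within the scatter) showed no movement beyond the scatter. Compound 4 is therefore estimated at about 38000 nM in this assay, within a range of 18000 nM to 80000 nM.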

Compound 4, half-maximal inhibitory concentration: 26000 nM
The estimate for compound 4 lay 1.5-fold (0.16 log units) above the measured number; measured number inside the range.
By their numbers in this assay, from the lowest: compounds 4, 2, 3 and 1 (each within the scatter of the next).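

In this assay, 4-chlorophenyl in place of 3,4-dimethylphenyl on the aromatic nitrogen gives a 1.5-fold lower number from compound 3 to compound 4 (0.19 log units; within the scatter). This is a second swap at this position that stays within the scatter, now on the core of compound 3 rather than that of compound 1, and it changes two methyl groups for one chlorine. No available measurement explains the step.

Still open, going by these compounds, is whether an amine or a carboxylic acid on this aromatic ring would move the number beyond the scatter. The same question applies to a longer chain in place of the ring.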